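A few compounds are considered here, and "the series" means these few. Any claim that something is new, unique, unknown or untested is made for them only; others in the source may bear on it.

Working notes on the series. Compound 1 `Oc1cccc(-c2ccc3c(-c4ccoc4)c(O)ccc3c2)c1` gives 89% in an in vitro assay on Sf9 cells for binding affinity to 17-beta-hydroxysteroid dehydrogenase type 1 (Homo sapiens), read by scintillation counting, with a stated time of 10 min, tested at 1 uM; on this read-out higher numbers stand for a stronger effect at the one concentration tested and lower numbers for a weaker effect. Compound 2 `O=C(O)c1cccc(-c2c(O)ccc3cc(-c4cccc(O)c4)ccc23)c1` gives 80% in this assay; of the two numbers measured it is the nearer to the bottom, though a number 9 percentage points lower from compound 1 to compound 2 (within the scatter) lies within the scatter. Compound 3 `CC(=O)Nc1cccc(-c2c(O)ccc3cc(-c4cccc(O)c4)ccc23)c1` differs from compound 2 by acetamido in place of carboxy on an aromatic carbon, on an aromatic carbon of a six-membered aromatic ring of carbon only, meta to a large group. Going by the values given here, the only measured step, a number 9 percentage points lower from compound 1 to compound 2 (within the scatter), concerned another group at another place and stayed within the scatter, so no step beyond the scatter is expected in this assay here either. Compound 3 is estimated at 78%, with a range of 55% to 92%. The expected step is therefore a number 2 percentage points lower from compound 2 to compound 3 (within the scatter).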

Compound 3, a percentage reported as inhibition, at one concentration (the size of the read-out at that concentration, not a potency): 82%
Compound 3: the middle estimate sits 4 percentage points below what was measured; measured number inside the range.
By their numbers in this assay, from the lowest: compounds 2, 3 and 1 (each within the scatter of the next).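

Going by these compounds alone, at this position, on an aromatic carbon meta to a large group, acetamido in place of carboxy gives a number 2 percentage points higher from compound 2 to compound 3 (within the scatter) in this assay, the first reading of a change to the carboxy group itself. The two groups can therefore be exchanged here without a step beyond the scatter, at the one concentration tested. No measurement bears on why this exchange leaves the read-out within the scatter. From the compounds shown here alone, whether an amine or a longer acyl chain at this position would also stay within the scatter remains open. Also open, going by these compounds, is whether compound 2 and compound 3 would separate at another concentration.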